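Aryl triazole esters at the assay limit

The source may hold more compounds than are shown below. What is called first, only, known or untested is meant among the compounds shown, and "the series" means these compounds.

In a functional assay on A549 cells (Homo sapiens) for antiproliferative activity, read by MTT assay, with a stated time of 48 h (a higher number here means a weaker inhibitor, a lower number a stronger inhibitor), compound 1 `C/C(=C\CC/C(C)=C/CC[C@@H]1[C@@]2(C)CCC(=O)C(C)(C)[C@H]2CC[C@@]1(C)O)CC/C=C(\C)C(=O)OCc1cn(-c2ccccc2C(F)(F)F)nn1` gives > 150000 nM, a limit and not a number. Compound 2 `C/C(=C\CC/C(C)=C/CC[C@@H]1[C@@]2(C)CCC(=O)C(C)(C)[C@H]2CC[C@@]1(C)O)CC/C=C(\C)C(=O)OCc1cn(-c2ccc(Cl)cc2)nn1` gives > 150000 nM, likewise a limit. Compound 2 therefore stands at the limit of > 150000 nM in this assay, at which 2 of the 2 values shown sit. Among the compounds with values here, the only measured step is a step that the two limits leave unreadable from compound 1 to compound 2, so it offers no size to carry over. Compound 3 `C/C(=C\CC/C(C)=C/CC[C@@H]1[C@@]2(C)CCC(=O)C(C)(C)[C@H]2CC[C@@]1(C)O)CC/C=C(\C)C(=O)OCc1cn(-c2cccc(O)c2)nn1` brings 3-hydroxyphenyl in place of 4-chlorophenyl on an aromatic nitrogen. No step beyond the scatter is expected in this assay, in either direction. The expected change is a number no higher from compound 2 to compound 3 (the limit leaves the size open). Compound 3 is estimated at 150000 nM, with an expected range of 70000 nM to 300000 nM.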

Compound 3, half-maximal inhibitory concentration: 42800 nM
Beside the measured number, compound 3's estimate is 3.5-fold (0.54 log units) above it, outside the stated range (below it).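

Among the aryl groups shown on this triazole nitrogen, only 3-hydroxyphenyl brings the read-out within the measurable range of this assay, giving an at least 3.5-fold lower number from compound 2 to compound 3 (0.54 log units; beyond the scatter) and an at least 3.5-fold lower number from compound 1 to compound 3 (0.54 log units; beyond the scatter). The exchange for 4-chlorophenyl also adds 1 hydrogen-bond donor and 1 hydrogen-bond acceptor, although the data do not tie the gain to either. The other two compounds remain at a limit: the limit of > 150000 nM in this assay, at which 2 of the 3 values shown sit.

From the compounds shown here alone, whether the hydroxyl itself is needed remains open. An amine or a methoxy group in its place would test this, and the true size of both steps is also unresolved.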